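Ring exchange on compound 2: expected half-life

This account rests on a few compounds, and the source may have more. Where it says the series, first, only, none or still open, it means among the compounds named here.

In an ADME assay on microsomes from liver (Homo sapiens) for metabolic stability (on this read-out higher numbers stand for a longer-lived compound and lower numbers for a shorter-lived compound), compound 2 (`CC(C)C(c1ccc(-c2ccc3cccc(F)c3c2)[nH]c1=O)C1SC(=O)NC1=O`) gives 1.87 h and compound 3 (`CC(C)[C@H](C[C@H]1OC(=O)NC1=O)c1ccc(-c2ccc3cccc(F)c3c2)[nH]c1=O`) gives 1.68 h, which lie within the scatter of each other. Compound 1 (`CC(C)C(CC1C(=O)NC(=O)N1C)c1ccc(-c2ccc3cccc(F)c3c2)[nH]c1=O`) gives 0.153 h and sits far lower than both. Compound 4 (`CC(C)C(c1ccc(-c2ccc3cccc(F)c3c2)[nH]c1=O)C1C(=O)NC(=O)N1C`) has 3-methyl-2,5-dioxoimidazolidin-4-yl in place of 2,4-dioxo-1,3-thiazolidin-5-yl on a saturated chain carbon bound to an aromatic carbon and a saturated chain carbon. Among the compounds with values here, the one measured step bearing on this is large, a 12-fold higher number from compound 1 to compound 2 (1.09 log units; beyond the scatter) and runs the opposite way. It starts from the (3-methyl-2,5-dioxoimidazolidin-4-yl)methyl group, so only part of it is expected to reverse. The expected shortening in this assay is a 3.4-fold lower number from compound 2 to compound 4 (0.53 log units; beyond the scatter) and lies beyond the scatter. For compound 4 the estimate is 0.55 h with an expected range of 0.18 h to 1.6 h for now.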

Compound 4, half-life: 0.375 h
Beside the measured number, compound 4's estimate is 1.5-fold (0.17 log units) above it, within the range that was stated.
By their numbers in this assay, from the lowest: compound 1; then compound 4; then compounds 3 and 2 (each within the scatter of the next).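

In this assay the ring exchange alone, on the same saturated chain carbon, gives a 5.0-fold lower number from compound 2 to compound 4 (0.70 log units; beyond the scatter) and so accounts for part of the earlier gap. Going from the (3-methyl-2,5-dioxoimidazolidin-4-yl)methyl group to 3-methyl-2,5-dioxoimidazolidin-4-yl gives a 2.5-fold higher number from compound 1 to compound 4 (0.39 log units; beyond the scatter), so the ring and the methylene link each carry part of the difference between compound 1 and compound 2. No available evidence explains either step.

Open, from the compounds shown here alone, is whether 2,4-dioxo-1,3-thiazolidin-5-yl behaves the same on a methylene link. Also open, going by these compounds, is how a carboxylic acid or an open-chain amide would fare at this position.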